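The compounds below may be only part of what the source reports. "The series", "measured", "known", "first", "only" and "open" are said of these compounds alone.

The shared core appears in compound 1 `FC(F)(F)c1ccc(-c2ccc3c(NCCCNCc4ccco4)ccnc3c2)cc1` and compound 2 `CCC(CC)c1ccc2c(NCCCNCc3ccco3)ccnc2c1`. In an ADME assay for permeability, using PAMPA, with a stated time of 30 min, at pH 7.4 (on this read-out lower numbers stand for lower permeability and higher numbers for higher permeability), compound 1 gives 237 10^-6 cm/s, while compound 2 gives 23 10^-6 cm/s. Compound 2 thus stands lowest of the two numbers, its nearest neighbour being compound 1, reached by a 10-fold lower number from compound 1 to compound 2 (1.01 log units; beyond the scatter) when pentan-3-yl took the place of 4-(trifluoromethyl)phenyl on an aromatic carbon. Compound 3 `CN(C)c1cccc(Oc2ccc3c(NCCCNCc4ccco4)ccnc3c2)c1` remains to be measured in this assay. It differs from compound 2 in one place: 3-(dimethylamino)phenoxy in place of pentan-3-yl on an aromatic carbon. Going by the values given here, only one measured step bears on this change, a 10-fold lower number from compound 1 to compound 2 (1.01 log units; beyond the scatter), where a group holding one six-membered aromatic ring of carbon only gave way to pentan-3-yl and the number fell by a large margin. The step to compound 3 runs the other way, returning a group with one six-membered aromatic ring of carbon only to that position, so a rise beyond the scatter is expected, although 3-(dimethylamino)phenoxy is not 4-(trifluoromethyl)phenyl and the rise need not retrace the whole step. Compound 3 is therefore expected to give 110 10^-6 cm/s, within 35 10^-6 cm/s to 300 10^-6 cm/s. That estimate amounts to an expected step of a 4.8-fold higher number from compound 2 to compound 3 (0.68 log units; beyond the scatter) in this assay.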

Compound 3, apparent permeability: 317 10^-6 cm/s
Estimate against measurement, compound 3: 2.9-fold (0.46 log units) below; measured number above the stated range.
By their numbers in this assay, from the lowest: compound 2; then compounds 1 and 3 (each within the scatter of the next).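

Compound 3 shows that a high number at this position in this assay does not depend on 4-(trifluoromethyl)phenyl: with 3-(dimethylamino)phenoxy in place of pentan-3-yl, the step is large (a 14-fold higher number from compound 2 to compound 3 (1.14 log units; beyond the scatter)), while the comparison with the earlier ring-bearing group stays within the scatter (a 1.3-fold higher number from compound 1 to compound 3 (0.13 log units; within the scatter)). The two groups at this place thus cannot be told apart on this read-out, although both carry one six-membered aromatic ring of carbon only and differ in what is attached to that ring and in how it is joined to the core, so among these three compounds only compound 2, with no ring at this place, stands apart. Nothing shown accounts for this difference or says which feature of the entering groups matters.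

The compounds shown leave open whether an aromatic ring is what counts, since a cyclohexyl group, which would keep a ring without aromaticity, does not appear among them. They also leave open how this position would read with a carboxylic acid or a primary amine on the ring of the phenoxy group.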